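Chloro for fluoro on the phenoxy group of compound 1

The compounds below may be only part of what the source reports. "The series", "measured", "known", "first", "only" and "open" are said of these compounds alone.

Compound 1 `CCc1nn(C)c(CO/N=C/c2c(C)nn(C)c2Oc2ccc(F)cc2)c1Cl` has been tested in a functional assay on SMMC-7721 cells (Homo sapiens) for inhibition, read by MTT assay, with a stated time of 72 h, tested at 25 uM; on this read-out lower numbers stand for less inhibition and higher numbers for more inhibition at the one concentration tested (going by the name of the read-out). In this assay compound 1 gives < 80%, which is a limit of the assay and not a number. Compound 2 `Cc1nn(C)c(Oc2ccc(Cl)cc2)c1/C=N\OCc1c(Cl)c(-c2ccc(F)cc2)nn1C` carries a 4-chlorophenoxy group and shows 80% in this assay. Compound 1 stands only at the limit of < 80% in this assay, at which 1 of the 2 values shown sits, and so nothing can be said about the distance between the two values. Going by the values given here, no measured step exists between compounds that differ in one place.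

Compound 3 `CCc1nn(C)c(CO/N=C/c2c(C)nn(C)c2Oc2ccc(Cl)cc2)c1Cl` differs from compound 1 by chloro in place of fluoro on an aromatic carbon. Among the compounds with values here, no step of this kind has been measured, so the size and direction of the expected change rest on the two values alone and on the structural change itself. The step that the limit leaves unreadable from compound 1 to compound 3 is expected to stay within the scatter or to run slightly upward. Compound 3 is estimated to give 68% in this assay, with a range from 45% to 85%.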

Compound 3, a percentage reported as inhibition, at one concentration (the size of the read-out at that concentration, not a potency): < 80%
Compound 3: a limit, no number; the forecaster's own chance of this, stated with the estimate: 40%; the middle value does not contradict the limit.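

Compound 1 and compound 3 each give a limit of the assay and not a number in this assay, so no step between them can be read: the limit of < 80% in this assay, at which 2 of the 3 values shown sit.

The compounds shown leave open whether 4-chlorophenoxy in place of 4-fluorophenoxy on the shared core changes the read-out at all, and in which direction.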